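This account rests on a few compounds, and the source may have more. Where it says the series, first, only, none or still open, it means among the compounds named here.

In a functional assay on a cell-free system (Platelet, plasma, Homo sapiens) for inhibition, read by turbidimetry, with a stated time of 3 min (on this read-out lower numbers stand for stronger inhibition and higher numbers for weaker inhibition), three compounds that share one core differ only in the group on the carbonyl carbon. Compound 1 `COc1ccc(-n2nc(C(=O)N3CCCCC3)cc2-c2ccc(Cl)cc2)nn1` gives 41 nM, and compound 2 `COc1ccc(-n2nc(C(=O)Nc3ccncc3)cc2-c2ccc(Cl)cc2)nn1` gives 110 nM. Compound 3 `COc1ccc(-n2nc(C(=O)OCCC(C)C)cc2-c2ccc(Cl)cc2)nn1` gives 1330 nM, the highest number of the three. Compound 4 `COc1ccc(-n2nc(CCC(=O)N3CCCCC3)cc2-c2ccc(Cl)cc2)nn1` departs from compound 3 by one change: 2-((piperidin-1-yl)carbonyl)ethyl in place of isopentyloxycarbonyl on an aromatic carbon. In words, 2-((piperidin-1-yl)carbonyl)ethyl stands in place of isopentyloxycarbonyl on an aromatic carbon.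

The closest evidence is the large step of a 32-fold higher number from compound 1 to compound 3 (1.51 log units; beyond the scatter), which links the piperidin-1-yl amide to the isopentyloxy group. The large step of a 12-fold higher number from compound 2 to compound 3 (1.08 log units; beyond the scatter) and the modest step of a 2.7-fold higher number from compound 1 to compound 2 (0.43 log units; beyond the scatter) show that both measured amides give lower numbers than compound 3. However, compound 4 carries its carbonyl on the ethyl chain, not on the aromatic carbon, and no measured compound tests that change. A lower number than for compound 3 is therefore expected, but only part of the full step from compound 1.

The expected change is a 4.4-fold lower number from compound 3 to compound 4 (0.65 log units; beyond the scatter). Compound 4 is estimated at 300 nM, with an expected range from 60 nM to 1500 nM.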

Compound 4, half-maximal inhibitory concentration: 920 nM
Beside the measured number, compound 4's estimate is 3.1-fold (0.49 log units) below it; the measured number falls inside the stated range.
By their numbers in this assay, from the lowest: compound 1; then compound 2; then compounds 4 and 3 (each within the scatter of the next).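

In this assay, keeping the piperidin-1-yl amide but placing an ethyl chain between its carbonyl and the aromatic carbon gives a 22-fold higher number from compound 1 to compound 4 (1.35 log units; beyond the scatter), so the piperidine amide alone does not carry the low number of compound 1. The same group also compares poorly with the other amide, with an 8.4-fold higher number from compound 2 to compound 4 (0.92 log units; beyond the scatter), while a 1.4-fold lower number from compound 3 to compound 4 (0.16 log units; within the scatter) lies within the scatter, leaving the ethyl-linked amide and the ester of compound 3 indistinguishable even though compound 3 has its carbonyl directly on the aromatic carbon. Nothing available explains this loss.

The compounds shown leave open whether a single methylene link in place of the ethyl chain would restore the lower number. They also leave open how a morpholine amide or a carboxylic acid on the aromatic carbon would compare with the piperidin-1-yl amide.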